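Swapping a methoxy group for hydrogen on compound 1

The source may report more compounds than this note shows. Statements on the series, on what has been measured and on what is new or still open speak of the compounds shown alone.

In an ADME assay on HEK293 cells (Homo sapiens) for cytotoxicity, read by MTT assay, with a stated time of 48 h (a higher number here means a weaker inhibitor, a lower number a stronger inhibitor), compound 1 (`COc1ccc(-c2nc(SCC(=O)c3sc(-c4ccccc4)nc3C)[nH]c(=O)c2C#N)cc1`) gives 76200 nM as its result. Among the compounds with values here, this is the only number available so far, so it cannot yet be ranked against any other compound. Compound 2 (`COc1ccc(-c2nc(SCC(=O)c3sc(-c4ccc(Cl)cc4)nc3C)[nH]c(=O)c2C#N)cc1`) offers no comparison, as the entry for compound 2 reads "not determined" (no result reported) and gives no number.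

The next compound to be measured is compound 3 (`Cc1nc(-c2ccccc2)sc1C(=O)CSc1nc(-c2ccccc2)c(C#N)c(=O)[nH]1`). It keeps the core of compound 1 and differs in one place: hydrogen in place of methoxy on an aromatic carbon, para to a large group, which turns 4-methoxyphenyl into phenyl (hydrogen in place of methoxy on an aromatic carbon).

Within the data shown here, no measured pair here shows what this swap does in this assay so far. Among the measured compounds shown here, the only anchor is compound 1 at 76200 nM in that test, and no change in either direction beyond the usual scatter is expected. The estimate for the step is a 1.0-fold higher number from compound 1 to compound 3 (0.02 log units; within the scatter) in size, which would be too small to count as a real change. For compound 3 the expected value is 80000 nM with an estimated range of 35000 nM to 180000 nM around it.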

Compound 3, half-maximal inhibitory concentration: 93500 nM
Compound 3: the middle estimate sits 1.2-fold (0.07 log units) below what was measured; measured number inside the range.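

In this assay, within the data shown here, the first measured pair that differs in one place gives a 1.2-fold higher number from compound 1 to compound 3 (0.09 log units; within the scatter) and so shows no real change when methoxy is replaced by hydrogen. On this aromatic carbon, para to a large group, compound 1 and compound 3 cannot be told apart, so for this pair the methoxy group makes no difference that can be read beyond the usual spread of repeated measurements. Nothing measured here explains why the two compounds read alike.

A single pair cannot show whether this carbon would tolerate every group in the same way, and an amine, a carboxylic acid or a longer chain such as ethoxy in the same place could give a different result. Any step to compound 2 cannot be read, as it has no number, so what a chlorine on the other phenyl ring does in this assay also remains open.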